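Amide nitrogen substituent and cytotoxicity: working notes

A few compounds are considered here, and "the series" means these few. Any claim that something is new, unique, unknown or untested is made for them only; others in the source may bear on it.

Compound 1 `C=CC1=C(C(=O)NCc2ccc(C)cc2)C(c2ccc(F)cc2)OC1` has been measured in a functional assay on A549 cells (Homo sapiens) for cytotoxicity, read by MTT assay, with a stated time of 24 h (a lower number here means a stronger inhibitor, a higher number a weaker inhibitor), and there compound 1 gives > 100000 nM, which is a limit of the assay rather than a number. Compound 2 `C=CC1=C(C(=O)Nc2ccccc2)C(c2ccc(Cl)c(Cl)c2)OC1` in this assay gives > 100000 nM, likewise a limit. Compound 3 `C=CC1=C(C(=O)NC(C)(C)C)C(c2ccc(Cl)c(Cl)c2)OC1` in this assay gives > 100000 nM, also a limit. Among the compounds with values here, the only one-place step among the measured compounds, a step that the two limits leave unreadable from compound 2 to compound 3, cannot be read in size because of the limit of > 100000 nM in this assay, at which 3 of the 3 values shown sit.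

Compound 4 `C=CC1=C(C(=O)NC(C)(C)C)C(c2ccc(F)cc2)OC1` differs from compound 1 by tert-butyl in place of 4-methylbenzyl on an amide-type nitrogen. This is the same kind of exchange at the amide nitrogen as from compound 2 to compound 3, where the value stayed at the limit, and compound 3 already carries the tert-butyl group on an otherwise matching core without leaving the limit. Within the data shown here, no measured step therefore gives a readable size or direction for the change, and in this assay compound 4 is expected to stay at the limit as well. The estimated step that the limit leaves unreadable from compound 1 to compound 4 is expected to be nothing readable. The estimate for compound 4 in this assay is 200000 nM, expected within 100000 nM to 1000000 nM.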

Compound 4, half-maximal inhibitory concentration: > 100000 nM
Compound 4 was reported as a limit; the forecaster's own chance of this, stated with the estimate: 85%; the middle value does not contradict the limit.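

The step between compound 1 and compound 4 cannot be read in size, because both values are limits: the limit of > 100000 nM in this assay, at which 4 of the 4 values shown sit.

The compounds shown leave open whether any substituent on the amide nitrogen brings a readable value in this assay, and what size a change at that place would have.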